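Working notes: cytotoxicity limits and a nitro replacement

The compounds below may be only part of what the source reports. "The series", "measured", "known", "first", "only" and "open" are said of these compounds alone.

Measured compounds so far:
compound 1 `Cc1ccc(Cn2cc(COc3ccc4c(=O)ccoc4c3)nn2)cc1`; in an ADME assay on L02 cells (Homo sapiens) for cytotoxicity, read by MTT assay, with a stated time of 48 h (on this read-out lower numbers stand for stronger inhibition and higher numbers for weaker inhibition), compound 1 gives > 300000 nM, a limit of the assay.
compound 2 `O=c1ccoc2cc(OCc3cn(Cc4ccccc4F)nn3)ccc12`; compound 2 gives > 300000 nM, again a limit.
compound 3 `CC(C)(C)c1ccc(Cn2cc(COc3ccc4c(=O)ccoc4c3)nn2)cc1`; compound 3 gives > 300000 nM, also a limit.

Compound 3 therefore stands at no number, only at a limit, and the same holds for both of its neighbours, since all three values sit at the same limit (the limit of > 300000 nM in this assay, at which 3 of the 3 values shown sit). The steps a step that the two limits leave unreadable from compound 1 to compound 2 and a step that the two limits leave unreadable from compound 1 to compound 3 are for that reason unreadable in size, and nothing in the measured set shows any change in this assay.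

Compound 4 `O=c1ccoc2cc(OCc3cn(Cc4ccc([N+](=O)[O-])cc4)nn3)ccc12` differs from compound 3 by nitro in place of tert-butyl on an aromatic carbon. Going by the values given here, no measured step bears readably on this change; the two steps available give no size at all. The step that the limit leaves unreadable from compound 3 to compound 4 is therefore expected to be none beyond the scatter. For compound 4 the estimate is 400000 nM, with a range from 150000 nM to 1000000 nM, and the most likely outcome is that the assay again reports only a limit.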

Compound 4, half-maximal inhibitory concentration: > 300000 nM
Compound 4 was reported as a limit; the forecaster's own chance of this, stated with the estimate: 85%; the middle value does not contradict the limit.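

In this assay compound 4 gives > 300000 nM, a limit of the assay. No step from compound 1, compound 2 or compound 3 to compound 4 can therefore be read: the limit of > 300000 nM in this assay, at which 4 of the 4 values shown sit.

The compounds shown leave open what number any of the four would give in this assay, and so the size of every step among them.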